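The source may hold more compounds than are shown below. What is called first, only, known or untested is meant among the compounds shown, and "the series" means these compounds.

Compound 3 `CCc1nc2ccc(OC3CCN(C(C)=N)CC3)cc2n1Cc1ccc2ccc(C(=N)N)cc2c1` stands lowest of the three measured compounds in an assay on isolated protein for inhibition of serine protease 1 (Bos taurus) (on this read-out lower numbers stand for stronger inhibition and higher numbers for weaker inhibition), with 7.7 nM. Compound 1 `CC(=N)N1CCC(Oc2ccc3ncn(Cc4ccc5ccc(C(=N)N)cc5c4)c3c2)CC1` gives 50 nM, and compound 2 `CC(=N)N1CCC(Oc2ccc3nc(CCC(=O)O)n(Cc4ccc5ccc(C(=N)N)cc5c4)c3c2)CC1` gives 18 nM. Compound 4 `CCCCc1nc2ccc(OC3CCN(C(C)=N)CC3)cc2n1Cc1ccc2ccc(C(=N)N)cc2c1` differs from compound 3 by ethyl in place of hydrogen on a saturated chain carbon, two bonds along the chain from an aromatic carbon. Among the compounds with values here, two measured steps bear on this: a 6.5-fold lower number from compound 1 to compound 3 (0.81 log units; beyond the scatter), and a 2.3-fold lower number from compound 2 to compound 3 (0.37 log units; beyond the scatter). Both steps show that an alkyl chain on the shared core lowered the number, while a carboxy on that chain raised it; neither step tests a longer plain chain itself, so only a small further lowering is expected, possibly none beyond the scatter. Compound 4 is therefore expected to give 6 nM, between 2.5 nM and 15 nM. The expected step is a 1.3-fold lower number from compound 3 to compound 4 (0.11 log units; within the scatter).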

Compound 4, inhibition constant: 5.7 nM
Beside the measured number, compound 4's estimate is 1.1-fold (0.02 log units) above it; measured number inside the range.
By their numbers in this assay, from the lowest: compounds 4 and 3 (each within the scatter of the next); then compound 2; then compound 1.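

In this assay, going from ethyl to butyl on the chain leaves the number unchanged within the scatter (a 1.4-fold lower number from compound 3 to compound 4 (0.13 log units; within the scatter)), so the read-out does not separate these two chain lengths at this position. The butyl chain still keeps the number lower than hydrogen on the aromatic carbon (an 8.8-fold lower number from compound 1 to compound 4 (0.94 log units; beyond the scatter)) and lower than the carboxy-ended chain (a 3.2-fold lower number from compound 2 to compound 4 (0.50 log units; beyond the scatter)), both beyond the scatter. Nothing measured here explains this result. On these data alone, whether a longer chain, or an amine at the end of the chain, would keep the number at this level remains open.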